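A few compounds are considered here, and "the series" means these few. Any claim that something is new, unique, unknown or untested is made for them only; others in the source may bear on it.

Compound 1, `Nc1nc(OCC(F)(F)F)c2ncn(/C=C3/CC3(CO)CO)c2n1`: in an ADME assay on Akata cells (Homo sapiens) for cytotoxicity, with a stated time of 7 days (a lower number here means that less compound is tolerated, a higher number that more compound is tolerated), compound 1 reaches only the assay limit of > 20000 nM.
Compound 2, `C=CCOc1nc(N)nc2c1ncn2/C=C1/CC1(CO)CO`: in this assay compound 2 likewise stops at the assay limit of > 20000 nM.

Compound 2 therefore has no number of its own in this assay; its value is a limit, and both values shown sit at the limit of > 20000 nM in this assay, at which 2 of the 2 values shown sit. For the measured compounds named here, the one step between measured compounds is a step that the two limits leave unreadable from compound 1 to compound 2; with both of its ends at the limit, its size stays unreadable.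

Compound 3, `CC(C)CNc1nc(N)nc2c1ncn2/C=C1/CC1(CO)CO`, is not yet measured. It differs from compound 2 in one place: isobutylamino in place of allyloxy on an aromatic carbon. Going by the values given here, no measured step involves this kind of change, and the only measured step gives no size, so there is no direction to read from the data.

With both measured compounds at the limit, the expected outcome for compound 3 is again that more compound is tolerated than the assay can report, and the expected step that the limit leaves unreadable from compound 2 to compound 3 is within scatter. Compound 3 is estimated at 25000 nM, between 10000 nM and 80000 nM.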

Compound 3, half-maximal cytotoxic concentration: > 24000 nM
Compound 3: a limit, no number; the forecaster's own chance of this, stated with the estimate: 75%; the middle value does not contradict the limit.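

In this assay compound 3 gives > 24000 nM, which is a limit and not a number. Compound 1 and compound 2 also stand at limits, so neither step to compound 3 can be read. The compounds shown leave open the actual half-maximal cytotoxic concentration of each, and whether isobutylamino in place of allyloxy changes it at all.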